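The source may report more compounds than this note shows. Statements on the series, on what has been measured and on what is new or still open speak of the compounds shown alone.

In an assay on isolated protein for inhibition of Maltase-glucoamylase (Homo sapiens) (on this read-out higher numbers stand for weaker inhibition and lower numbers for stronger inhibition), three compounds built on a shared core have been measured. Compound 1 `C=C1CC[C@@H]2[C@](C)(CO)[C@H](O)CC[C@@]2(C)[C@@H]1/C=C/C1=C/C(=C/c2ccco2)OC1=O` gives 100000 nM. Compound 3 `C=C1CC[C@@H]2[C@](C)(COC(=O)c3cccnc3)[C@H](OC(=O)c3cccnc3)CC[C@@]2(C)[C@@H]1/C=C/C1=C/C(=C/c2ccco2)OC1=O` gives 36000 nM. Compound 2 `C=C1CC[C@@H]2[C@](C)(COC(=O)c3cccnc3)[C@H](OC(=O)c3cccnc3)CC[C@@]2(C)[C@@H]1/C=C/C1=C/C(=C\c2ccccc2)OC1=O` gives 16000 nM, the lowest of the three numbers and so the strongest inhibition of the set; its gap to compound 3 and its gap to compound 1 both lie beyond the usual scatter of repeated measurements.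

Compound 4 `C=C1CC[C@@H]2[C@](C)(COC(=O)c3cccnc3)[C@H](OC(=O)c3cccnc3)CC[C@@]2(C)[C@@H]1/C=C/C1=C/C(=C\c2ccc(OC)cc2)OC1=O` has not yet been measured. It differs from compound 2 in one place: methoxy in place of hydrogen on an aromatic carbon. Among the compounds with values here, no measured pair in this set shows the same change, so the data give no direction for it. The expectation is therefore a small step, a 1.1-fold lower number from compound 2 to compound 4 (0.06 log units; within the scatter), which is expected to stay within the scatter. On that basis compound 4 is estimated to give 14000 nM in this assay, within a range from 5000 nM to 40000 nM.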

Compound 4, half-maximal inhibitory concentration: 11000 nM
The estimate for compound 4 lay 1.3-fold (0.10 log units) above the measured number; measured number inside the range.
By their numbers in this assay, from the lowest: compounds 4 and 2 (each within the scatter of the next); then compound 3; then compound 1.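

Phenyl to 4-methoxyphenyl gives, in this assay, a 1.5-fold lower number from compound 2 to compound 4 (0.16 log units; within the scatter) and is the first measured comparison in this set between compounds that differ in one place. On this aromatic carbon, para to a large group, methoxy in place of hydrogen therefore leaves compound 4 and compound 2 indistinguishable in this read-out, so the position accepts this group without a difference that can be told from the scatter. No measurement shown here offers an explanation for this result.

As far as these compounds go, whether the same holds for other groups on this carbon, such as a hydroxyl, an amine, a carboxylic acid or a longer alkoxy chain, remains open. The compounds shown also leave open how methoxy would read on another carbon of this ring.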